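This account rests on a few compounds, and the source may have more. Where it says the series, first, only, none or still open, it means among the compounds named here.

Measured compounds in an ADME assay on WI-38 cells (Homo sapiens) for cytotoxicity, read by MTT assay, with a stated time of 48 h; on this read-out higher numbers stand for weaker inhibition and lower numbers for stronger inhibition:

- compound 1, `COc1ccc(NC(=S)OCCNC(=O)C(C)(C)Oc2ccc(Cl)cc2)cc1`: 780000 nM
- compound 2, `COc1ccc(NC(=S)OCCNC(=O)c2cccnc2)cc1`: 781000 nM
- compound 3, `Cc1ccc(NC(=S)OCCNC(=O)C(C)(C)Oc2ccc(Cl)cc2)cc1`: its result is a limit of this assay, > 800000 nM

Compound 1 and compound 3 share a core and differ in one place, (methyl in place of methoxy on an aromatic carbon); the step is an at least 1.0-fold higher number from compound 1 to compound 3 (0.01 log units; that floor lies within the scatter), and the value of compound 3 sits at the limit of > 800000 nM in this assay, at which 1 of the 3 values shown sits. Compound 2 carries a different core, and the difference between the two cores is not broken down here; its value and that of compound 1 lie within the scatter of each other.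

Compound 4, `Cc1ccc(NC(=S)OCCNC(=O)c2cccnc2)cc1`, is not yet measured. It relates to compound 2 by methyl in place of methoxy on an aromatic carbon, the same change as that from compound 1 to compound 3, set on the same kind of aromatic carbon. Since that earlier step was an at least 1.0-fold higher number from compound 1 to compound 3 (0.01 log units; that floor lies within the scatter), the step from compound 2 to compound 4 is expected to be of similar size, a 1.0-fold higher number from compound 2 to compound 4 (0.02 log units; within the scatter), with a fair chance that this assay reports only a limit for compound 4. The estimate for compound 4 in this assay is 820000 nM, between 450000 nM and 1500000 nM.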

Compound 4, half-maximal inhibitory concentration: > 800000 nM
Compound 4 gave a limit, no number; the forecaster's own chance of this, stated with the estimate: 55%; the middle value lies beyond the limit too.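

In this assay compound 4 gives > 800000 nM, which is a limit of the assay and not a number. Methyl in place of methoxy on the aromatic carbon therefore reads only as an at least 1.0-fold higher number from compound 2 to compound 4 (0.01 log units; that floor lies within the scatter), so neither core shows a step beyond the scatter for this change, and nothing here speaks against it carrying over from one core to the other. This does not show that the change has the same size on both cores, since neither methyl compound gives a number: the same change on two cores in this assay, an at least 1.0-fold higher number (0.01 log units; that floor lies within the scatter) from compound 1 to compound 3 and an at least 1.0-fold higher number (0.01 log units; that floor lies within the scatter) from compound 2 to compound 4; the limit leaves it open whether they differ.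

Still open, going by these compounds, is how far past the limit the two methyl compounds lie, and so whether this change moves the read-out at all on either core: the limit of > 800000 nM in this assay, at which 2 of the 4 values shown sit. Also open, on these data alone, is whether an amine or a carboxylic acid on the same aromatic carbon, para to a large group, would give a step beyond the scatter in this assay.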